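This account rests on a few compounds, and the source may have more. Where it says the series, first, only, none or still open, it means among the compounds named here.

Measured in a functional assay on HeLa cells (Homo sapiens) for inhibition, read by MTT assay, with a stated time of 48 h; a higher number here means a weaker inhibitor, a lower number a stronger inhibitor:
- compound 1 `CCc1ccc(-c2nc3ccccn3c2Sc2ccccc2)cc1`: 52100 nM
- compound 2 `CS(=O)(=O)c1ccc(-c2nc3ccccn3c2Sc2cccc3ccccc23)cc1`: 34600 nM

Only these two values are available, and they lie within the scatter of each other, so compound 1 stands level with compound 2. Compound 3 `Clc1ccc(-c2nc3ccccn3c2Sc2ccccc2)cc1` is the next to be read. It has chloro in place of ethyl on an aromatic carbon, para to a large group, the change from 4-ethylphenyl to 4-chlorophenyl: chloro in place of ethyl on an aromatic carbon. Going by the values given here, no measured pair isolates this change, so the expectation rests on little. With compound 1 at 52100 nM and compound 2 at 34600 nM, no step beyond the scatter is expected in this assay, and no direction is favoured. The estimated step is a 1.2-fold lower number from compound 1 to compound 3 (0.09 log units; within the scatter). For compound 3 the expected value is 42000 nM, with an estimated range of 16000 nM to 100000 nM.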

Compound 3, half-maximal inhibitory concentration: 62000 nM
Compound 3: the middle estimate sits 1.5-fold (0.17 log units) below what was measured; the range from low to high includes it.
By their numbers in this assay, from the lowest: compounds 2, 1 and 3 (each within the scatter of the next).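

Going by these compounds alone, the change from 4-ethylphenyl to 4-chlorophenyl is the first single-place comparison, and in this assay it gives a 1.2-fold higher number from compound 1 to compound 3 (0.08 log units; within the scatter). On this aromatic carbon, para to a large group, chloro with its 1 heavy atom and ethyl with its 2 heavy atoms therefore cannot be told apart by this read-out, though this rests on one pair alone. No measurement at hand bears on why the two groups read alike.

As far as these compounds go, whether an amine, a carboxylic acid or a longer chain such as butyl in this place would give a step beyond the scatter remains open. Also open, from the compounds shown here alone, is whether the same change would read alike on the core of compound 2, which differs from compound 1 in more than one place.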